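Aryl swap on the shared core: from fluorophenyl to trimethoxyphenyl

The compounds below may be only part of what the source reports. "The series", "measured", "known", "first", "only" and "open" are said of these compounds alone.

Among the compounds with values here, compound 3 (`C=CC(=O)Nc1cccc(NC(=O)CSc2nc(Nc3ccc(F)cc3)c3ccccc3n2)c1`) carries the lowest of the three numbers measured so far in a functional assay on NCI-H1975 cells (Homo sapiens) for inhibition, read by MTT assay, with a stated time of 72 h (on this read-out higher numbers stand for weaker inhibition and lower numbers for stronger inhibition), where compound 3 gives 4430 nM, although its distance to the others stays within the scatter. Compound 1 (`C=CC(=O)Nc1cccc(NC(=O)CSc2nc(Nc3ccccc3F)c3ccccc3n2)c1`) gives 6580 nM and compound 2 (`C=CC(=O)Nc1cccc(NC(=O)CSc2nc(Nc3cccc(OC)c3)c3ccccc3n2)c1`) gives 7940 nM in this assay. Within the data shown here, the steps that bear on the aryl group on the nitrogen are a 1.5-fold lower number from compound 1 to compound 3 (0.17 log units; within the scatter), a 1.8-fold lower number from compound 2 to compound 3 (0.25 log units; within the scatter) and a 1.2-fold higher number from compound 1 to compound 2 (0.08 log units; within the scatter); every one of them lies within the scatter, so the three aryl groups tried at this position have not moved the number. Compound 4 (`C=CC(=O)Nc1cccc(NC(=O)CSc2nc(Nc3cc(OC)c(OC)c(OC)c3)c3ccccc3n2)c1`) differs from compound 3 by 3,4,5-trimethoxyphenyl in place of 4-fluorophenyl on a nitrogen on an aromatic ring. Since the three aryl changes seen so far stayed within the scatter, the expectation for compound 4 is a step of a 1.2-fold higher number from compound 3 to compound 4 (0.09 log units; within the scatter), no further than the scatter in either direction. Compound 4 is therefore estimated at 5500 nM in this assay, expected to fall between 2000 nM and 15000 nM.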

Compound 4, half-maximal inhibitory concentration: > 50000 nM
Compound 4 ended at the assay's limit (the forecaster's own chance of this, stated with the estimate: 5%); middle value at least 9.0-fold (0.95 log units) from the limit.
By their numbers in this assay, from the lowest: compounds 3, 1 and 2 (each within the scatter of the next). At a limit, above all of these: compound 4.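

Compound 4 stands at a limit of this assay, which is not a number: the limit of > 50000 nM in this assay, at which 1 of the 4 values shown sits.

Even so, the steps can be read, and they show that the aryl group on this nitrogen can matter: an at least 11-fold higher number from compound 3 to compound 4 (1.05 log units; beyond the scatter), an at least 6.2-fold higher number from compound 2 to compound 4 (0.79 log units; beyond the scatter) and an at least 7.5-fold higher number from compound 1 to compound 4 (0.88 log units; beyond the scatter). Unlike the changes among compound 1, compound 2 and compound 3, all within the scatter, each of these lies beyond it, so the earlier flatness at this position does not extend to 3,4,5-trimethoxyphenyl.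

The compounds shown leave open whether a 4-methoxyphenyl or 3,5-dimethoxyphenyl group would stay with the first three compounds or go with compound 4. They also leave open how a 4-aminophenyl or 4-carboxyphenyl group on this nitrogen would behave in this assay.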